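This account rests on a few compounds, and the source may have more. Where it says the series, first, only, none or still open, it means among the compounds named here.

Compounds measured in a functional assay on CHO cells for positive allosteric modulation of metabotropic glutamate receptor 2 (Homo sapiens), with a stated time of 30 min; on this read-out higher numbers stand for an effect only at larger amounts of compound and lower numbers for an effect already at smaller amounts:
- compound 1, `CCCCn1ccc(N2CCC(c3ccccc3)CC2)c(C#N)c1=O`, gives 95 nM
- compound 2, `N#Cc1c(N2CCC(c3ccccc3)CC2)ccn(CCC2CC2)c1=O`, gives 178 nM
- compound 3, `N#Cc1c(N2CCC(c3ccccc3F)CC2)ccn(CC2CC2)c1=O`, gives 81 nM

Compound 3 carries the lowest number of the three. Its value and that of compound 1 are within the scatter of each other, so no order between them can be claimed; its number is lower than that of compound 2 beyond the scatter. Compound 4, `N#Cc1c(N2CCC(c3cc(F)cc(F)c3)CC2)ccn(CC2CC2)c1=O`, differs from compound 3 in one place: 3,5-difluorophenyl in place of 2-fluorophenyl on a saturated ring carbon, on a saturated ring carbon of a six-membered non-aromatic ring with one nitrogen, three ring bonds from the ring nitrogen.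

Among the measured compounds shown here, the only step measured among the three, a 1.9-fold higher number from compound 1 to compound 2 (0.27 log units; within the scatter), concerns the chain on the aromatic nitrogen and not the aryl ring, so it does not bear on this change. Compounds 1 and 3 differ in two places, and their two values show only that the fluorine on the aryl ring, together with the change of chain, leaves the number within the scatter. For the measured compounds named here, no measured step informs on moving fluorine across the aryl ring or adding a second one. Compound 4 is therefore expected to stay close to compound 3, with an estimated step of a 1.4-fold higher number from compound 3 to compound 4 (0.13 log units; within the scatter) in this assay. The estimate for compound 4 is 110 nM, in a range from 40 nM to 300 nM.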

Compound 4, half-maximal effective concentration: 151 nM
For compound 4 the middle estimate is 1.4-fold (0.14 log units) below the measured one; low and high end bracket the measured number.
By their numbers in this assay, from the lowest: compounds 3, 1, 4 and 2 (each within the scatter of the next, the first and the last beyond it).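

In this assay, among the compounds shown here, the only measured change confined to the aryl ring, on a saturated ring carbon three ring bonds from the ring nitrogen, is a 1.9-fold higher number from compound 3 to compound 4 (0.27 log units; within the scatter). Replacing 2-fluorophenyl with 3,5-difluorophenyl adds one fluorine and changes where the ring is substituted, yet the number stays within the scatter, so this position accepts both fluorinated phenyl groups on this read-out. Nothing available accounts for the size of this step.

The compounds shown leave open whether a single fluorine elsewhere on the phenyl ring, or a chlorine, methoxy or trifluoromethyl group in its place, would keep the number in this range. Also open, from the compounds shown here alone, is how a pyridine ring in place of the phenyl ring would fare at this position.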